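The source may report more compounds than this note shows. Statements on the series, on what has been measured and on what is new or still open speak of the compounds shown alone.

Working notes on the series. Three members have been tested in a functional assay on HeLa cells (Homo sapiens) for antiproliferative activity, read by CCK-8 assay, with a stated time of 72 h, tested at 2 uM; a higher number here means a stronger effect of the compound at the concentration tested, a lower number a weaker effect. Compound 1, `Nc1ccccc1NC(=O)c1ccc(CSC(=S)N2CCc3ccccc32)cc1`, gives 38% in this assay. Compound 2, `Nc1ccccc1NC(=O)c1ccc(CSC(=S)N2CCN(c3ccc(F)cc3)CC2)cc1`, gives 60.8%. Compound 3, `Nc1ccccc1NC(=O)c1ccc(CSC(=S)N(Cc2ccccc2)Cc2ccccc2)cc1`, gives 1%. Among these three numbers compound 2 stands highest: the nearest, compound 1, lies below it by a gap that is beyond the scatter, and the furthest, compound 3, lies below it by a gap also beyond the scatter. No pair of these compounds differs in a single place, so no step within the measured set can be isolated.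

Compound 4, `Nc1ccccc1NC(=O)c1ccc(CSC(=S)N2CCN(Cc3cccnc3)CC2)cc1`, has not been measured in this assay. It differs from compound 2 as follows: (pyridin-3-yl)methyl in place of 4-fluorophenyl on an amine nitrogen in a ring. Among the compounds with values here, the measured compounds give no direct precedent for this change, so the expectation rests on compound 2 alone as the starting point. Given that the group leaving and the group entering are of equal size and the ring nitrogen keeps its setting, the step from compound 2 is expected to be modest and more likely downward than upward, though a result within the scatter would not surprise: the estimated step is a number 15.8 percentage points lower from compound 2 to compound 4 (beyond the scatter). Compound 4 is therefore expected to give about 45% in this assay, with a likely range from 15% to 70%.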

Compound 4, a percentage reported as inhibition, at one concentration (the size of the read-out at that concentration, not a potency): 69.7%
Compound 4: the middle estimate sits 24.7 percentage points below what was measured, within the range that was stated.
By their numbers in this assay, from the lowest: compound 3; then compound 1; then compounds 2 and 4 (each within the scatter of the next).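

In this assay, within the data shown here, the only single-place comparison reads a number 8.9 percentage points higher from compound 2 to compound 4 (within the scatter) and so gives this position its first direct reading. On the amine nitrogen in the six-membered non-aromatic ring with 2 nitrogen, (pyridin-3-yl)methyl, which brings a ring hetero atom and a hydrogen-bond acceptor, can stand in place of 4-fluorophenyl with the two compounds remaining within the scatter of each other, so neither the fluorine nor a carbon-only aromatic ring is required at this position in this pair. No measured property bears on this result, and it carries no explanation.

The change alters the aromatic ring and the way it is attached in one step, so a benzyl group or a pyridin-3-yl group set directly on the same nitrogen would be needed to tell those two parts apart. Steps from compound 4 to compound 1 or compound 3 cannot be read, and a single tested concentration leaves potency at this position open, as it does whether a smaller group such as methyl or an unsubstituted amine hydrogen is tolerated there.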